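This account rests on a few compounds, and the source may have more. Where it says the series, first, only, none or still open, it means among the compounds named here.

Working notes, cytotoxicity series. Compound 1 `COc1cccc2[nH]c(C(=O)N[C@@H](CC(C)C)C(=O)N[C@H](C=O)C[C@@H]3CCNC3=O)cc12`, compound 2 `COc1cccc2[nH]c(C(=O)N[C@@H](CC(C)C)C(=O)N[C@H](C#N)C[C@@H]3CCCNC3=O)cc12` and compound 3 `CC(C)C[C@H](NC(=O)c1cc2c(OC(F)(F)F)cccc2[nH]1)C(=O)N[C@H](C#N)C[C@@H]1CCCNC1=O` share a common core. In a toxicity assay on Vero C1008 cells (Chlorocebus sabaeus) for cytotoxicity, read by CellTiter-Glo (a lower number here means that less compound is tolerated, a higher number that more compound is tolerated), compound 1 gives only a limit, > 200000 nM. Compound 2 likewise reaches only a limit, > 200000 nM. Compound 3 also stands at a limit, > 100000 nM. The steps a step that the two limits leave unreadable from compound 1 to compound 2 and a step that the two limits leave unreadable from compound 2 to compound 3 are thus not readable in size, since every value shown sits at a limit (the limit of > 100000 nM in this assay, at which 1 of the 3 values shown sits, (the limit of > 200000 nM in this assay, at which 2 of the 3 values shown sit)). Compound 4 `CCOc1cccc2[nH]c(C(=O)N[C@@H](CC(C)C)C(=O)N[C@H](C#N)C[C@@H]3CCCNC3=O)cc12` differs from compound 3 by ethyl in place of trifluoromethyl on an oxygen on an aromatic ring. Among the compounds with values here, no measured step of readable size bears on this change, so in this assay no step beyond the scatter is expected. Compound 4 is expected to give 200000 nM, within 100000 nM to 400000 nM. The expected step is a step that the limit leaves unreadable from compound 3 to compound 4.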

Compound 4, half-maximal cytotoxic concentration: > 200000 nM
Compound 4 gave a limit, no number; the forecaster's own chance of this, stated with the estimate: 85%; the middle value sits exactly at the limit.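

Within the data shown here, compound 4 gives only a limit, as do compound 2 and compound 3, so no new step to compound 4 can be read. The compounds shown leave open whether trifluoromethoxy and ethoxy differ at all in this assay.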